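This account rests on a few compounds, and the source may have more. Where it says the series, first, only, none or still open, it means among the compounds named here.

Compound 1 `Cc1cc(NCc2nccn2C)n2nc(C)c(-c3ccccc3)c2n1`: 26900 nM
Compound 2 `Cc1cc(NCc2ccccn2)n2ncc(-c3ccc(C(F)(F)F)cc3)c2n1`: < 5000 nM
Compound 3 `Cc1cc(NCc2cccc[n+]2[O-])n2ncc(-c3ccccc3)c2n1`: 159000 nM

In a physicochemical assay for solubility, read by HPLC, using the shake flask method, measured as kinetic solubility, with a stated time of 2 h, at pH 7.4 (on this read-out lower numbers stand for lower solubility and higher numbers for higher solubility), compound 1 gives 26900 nM and compound 3 gives 159000 nM. For compound 2 the assay returns a limit rather than a number, < 5000 nM, which sits at the limit of < 5000 nM in this assay, at which 1 of the 3 values shown sits. Among the measured compounds shown here, compound 2 therefore stands at the low end of the values shown, and no measured step connects it to compound 1 or compound 3. Compound 4 `Cc1cc(NCc2ccccn2)n2ncc(-c3ccc(O)cc3)c2n1` has not yet been measured. It differs from compound 2 by hydroxy in place of trifluoromethyl on an aromatic carbon. In this assay an upward step, beyond the usual scatter, is expected, with the estimated step being an at least 4.0-fold higher number from compound 2 to compound 4 (0.60 log units; beyond the scatter). The solubility of compound 4 is expected to be about 20000 nM, within a range from 5000 nM to 80000 nM.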

Compound 4, solubility: 10900 nM
Compound 4: middle estimate off by 1.8-fold (0.26 log units), on the high side, and the stated range covers the measured number.
By their numbers in this assay, from the lowest: compound 4; then compound 1; then compound 3. At a limit, below all of these: compound 2.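

In this assay, hydroxy in place of trifluoromethyl on an aromatic carbon, para to a large group, gives an at least 2.1-fold higher number from compound 2 to compound 4 (0.33 log units; beyond the scatter) as the only measured step among these compounds. This shows that the position responds to this change by more than the usual scatter. From the compounds shown here alone, the figure for compound 2 is a limit, so the step is only a floor and its full size stays unknown: the limit of < 5000 nM in this assay, at which 1 of the 4 values shown sits.

Going by these compounds, how an amine or a carboxylic acid on this aromatic carbon would read in this assay remains open. So does whether the same change carries over to the core of compound 1.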